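This account rests on a few compounds, and the source may have more. Where it says the series, first, only, none or still open, it means among the compounds named here.

Working notes on the series, read in a functional assay on RAW264.7 cells (Mus musculus) for inhibition, read by Griess assay, with a stated time of 20 h; a higher number here means a weaker inhibitor, a lower number a stronger inhibitor. Compound 1 `Oc1ccc(C2=NN(c3ccc(Cl)cc3)C(c3cccc(Cl)c3)C2)cc1` offers no comparison point, since compound 1 gives "not determined" (no result reported). Going by the values given here, compound 2 `Oc1ccc(C2CC(c3ccccc3O)=NN2c2cccc(Cl)c2)cc1F` gives 2900 nM, the only number available in this assay, so its rank cannot yet be judged.

The next structure is compound 3 `Oc1ccc(C2=NN(c3cccc(Cl)c3)C(c3ccc(O)c(F)c3)C2)c(O)c1`. Relative to compound 2, it shows hydroxy in place of hydrogen on an aromatic carbon, meta to a hydroxy group and para to a large group, which turns 2-hydroxyphenyl into 2,4-dihydroxyphenyl. Among the compounds with values here, no measured pair shows what this change does, so the expectation rests on a single anchor and the structural change alone. A small move towards a stronger inhibitor is expected, probably not clearly beyond the usual scatter, and a move the other way cannot be excluded. The expected size of the change is a 1.3-fold lower number from compound 2 to compound 3 (0.12 log units; within the scatter). For compound 3 the estimated value is 2200 nM, with an expected range of 700 nM to 7000 nM.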

Compound 3, half-maximal inhibitory concentration: 3100 nM
Compound 3: middle estimate off by 1.4-fold (0.15 log units), on the low side; measured number inside the range.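

Going by these compounds alone, the added hydroxy, meta to a hydroxy group and para to a large group, is the first change at this position that can be read in this assay, and the result is a 1.1-fold higher number from compound 2 to compound 3 (0.03 log units; within the scatter) on going from 2-hydroxyphenyl to 2,4-dihydroxyphenyl. Within the data shown here, the single number for compound 2 could not show how this position responds, whereas this pair shows that the added hydroxy brings no readable gain or loss in inhibition. Nothing at hand bears on the reason for this flat result.

As far as these compounds go, with one step at one position, it remains open whether the flat result is particular to hydroxy or also holds here for other groups, such as methoxy, an amine or a carboxylic acid. From the compounds shown here alone, it also remains open whether the same hydroxy change would read the same way elsewhere on the shared core, and compound 1, which has no number, offers no help on this point.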